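Swapping a dimethylamino group for piperidinyl on a quinoline chain

The source may report more compounds than this note shows. Statements on the series, on what has been measured and on what is new or still open speak of the compounds shown alone.

Of the compounds shown here, two have been measured in an assay on nucleic acid for binding affinity to Nucleic Acid, read by spectrophotometry, at pH 7.5; a higher number here means weaker binding, a lower number tighter binding. Compound 1, `CC(C)NCCNc1ccnc2cc(Cl)ccc12`, carries a short isopropylamino tail on its core; in this assay compound 1 gives 17500 nM. Compound 2, `CN(C)CCC(NCCNc1ccnc2cc(Cl)ccc12)c1ccccc1`, has a longer tail bearing a phenyl group and a dimethylamino group, and in this assay compound 2 gives 7000 nM, the lower of the two values seen so far. The gap from compound 1 to compound 2 is larger than the usual scatter, so compound 2 binds more tightly than compound 1.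

Going by the values given here, compound 3, `Clc1ccc2c(NCCNC(CCN3CCCCC3)c3ccccc3)ccnc2c1`, keeps the whole framework of compound 2 and changes only one group: piperidin-1-yl in place of dimethylamino on a saturated chain carbon, three bonds along the chain from an amine nitrogen and an aromatic carbon. Among the compounds with values here, no pair of measured compounds shows this particular change, so there is no measured step to lean on. The step is expected to stay within the scatter, in the direction of slightly tighter binding, a 1.4-fold lower number from compound 2 to compound 3 (0.15 log units; within the scatter). Compound 3 is therefore estimated at 5000 nM, with a range from 2000 nM to 12000 nM.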

Compound 3, dissociation constant: 1000 nM
For compound 3 the middle estimate is 5.0-fold (0.70 log units) above the measured one; measured number outside the range, below it.
By their numbers in this assay, from the lowest: compound 3; then compound 2; then compound 1.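

In this assay, piperidin-1-yl in place of dimethylamino on this saturated chain carbon gives a 7.0-fold lower number from compound 2 to compound 3 (0.85 log units; beyond the scatter), a step beyond the usual scatter, so the group at the end of this chain clearly matters for binding. The change takes the group from 3 heavy atoms to 6 and closes a six-membered non-aromatic ring, while the counts of hydrogen-bond donors and acceptors stay the same and neither group carries a net charge. No measurement shown here explains why binding tightens with this change.

Going by these compounds alone, the single step cannot separate the larger size of the group from the presence of the ring, and a diethylamino group or a pyrrolidin-1-yl ring at the same place would help to tell the two apart. On these data alone, it also remains open whether the same swap would tighten binding to a similar degree on a chain without the phenyl group, or with a longer chain leading to the piperidin-1-yl group.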